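From 3-methylphenyl to 4-methylphenyl on a shared core

The source may hold more compounds than are shown below. What is called first, only, known or untested is meant among the compounds shown, and "the series" means these compounds.

Three compounds with one shared core have numbers in a functional assay on SW-620 cells (Homo sapiens) for cytotoxicity, read by sulforhodamine B assay, with a stated time of 48 h; a lower number here means a stronger inhibitor, a higher number a weaker inhibitor. Compound 1 `C[C@H]1CC[C@@H]2[C@@H](OC(=O)[C@]23CC(c2ccc(O)cc2)=NO3)[C@]2(C)C(=O)C=C[C@@]12O`, bearing 4-hydroxyphenyl, gives 89000 nM. Compound 2 `C[C@H]1CC[C@@H]2[C@@H](OC(=O)[C@]23CC(c2ccccc2F)=NO3)[C@]2(C)C(=O)C=C[C@@]12O`, bearing 2-fluorophenyl, gives 11000 nM. Compound 3 `Cc1cccc(C2=NO[C@]3(C2)C(=O)O[C@@H]2[C@H]3CC[C@H](C)[C@]3(O)C=CC(=O)[C@@]23C)c1`, bearing 3-methylphenyl, gives 15000 nM. That is the middle of the three numbers, although the nearest gap is a 1.4-fold higher number from compound 2 to compound 3 (0.13 log units; within the scatter), so those two cannot be told apart. The gap to the highest number is far clearer: a 5.9-fold lower number from compound 1 to compound 3 (0.77 log units; beyond the scatter).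

Compound 4 `Cc1ccc(C2=NO[C@]3(C2)C(=O)O[C@@H]2[C@H]3CC[C@H](C)[C@]3(O)C=CC(=O)[C@@]23C)cc1` is still unmeasured. It has the same atoms as compound 3, joined differently: 4-methylphenyl in place of 3-methylphenyl on a carbon with a double bond to nitrogen. In words, 4-methylphenyl stands in place of 3-methylphenyl on a carbon with a double bond to nitrogen. Among the measured compounds shown here, no measured pair isolates such a shift of one methyl group. The closest guide is the swap of 2-fluorophenyl for 3-methylphenyl, which stayed small. The larger steps all leave 4-hydroxyphenyl, such as an 8.1-fold lower number from compound 1 to compound 2 (0.91 log units; beyond the scatter), and a single compound cannot show whether that reflects the hydroxyl group or its place. In this assay the expected step is therefore small, a 1.2-fold higher number from compound 3 to compound 4 (0.08 log units; within the scatter), with no change expected beyond the scatter. For compound 4 the estimated value is 18000 nM, with an expected range from 8000 nM to 45000 nM.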

Compound 4, half-maximal inhibitory concentration: 2500 nM
For compound 4 the middle estimate is 7.2-fold (0.86 log units) above the measured one; measured number below the stated range.
By their numbers in this assay, from the lowest: compound 4; then compounds 2 and 3 (each within the scatter of the next); then compound 1.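

In this assay, among the compounds shown here, the change from 3-methylphenyl to 4-methylphenyl gains and loses no atom, yet it gives a 6.0-fold lower number from compound 3 to compound 4 (0.78 log units; beyond the scatter) and so shows that the place of one methyl group on the phenyl ring counts here, which no earlier pair could show. The step from 2-fluorophenyl is also beyond the scatter, at a 4.4-fold lower number from compound 2 to compound 4 (0.64 log units; beyond the scatter) and, with the step from compound 1 below, it makes compound 4 the strongest inhibitor of the four. With the group held in the same ring place, methyl in place of hydroxy gives a 36-fold lower number from compound 1 to compound 4 (1.55 log units; beyond the scatter) and this settles part of the earlier question, since the high number of compound 1 goes with the hydroxy group and not with that ring place alone.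

Still open, on these data alone, is whether other groups in that same ring place, such as methoxy, chlorine or an amine, would follow the methyl or the hydroxy, and how 2-methylphenyl would compare with the two methylphenyl compounds. Nothing available here explains why moving the methyl group or replacing the hydroxy group changes the number so much.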